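Adding One Methyl to Compound 2

The source may hold more compounds than are shown below. What is called first, only, known or untested is meant among the compounds shown, and "the series" means these compounds.

Measured so far in a functional assay on NCI-H460 cells (Homo sapiens) for antiproliferative activity; on this read-out lower numbers stand for stronger inhibition of growth and higher numbers for weaker inhibition of growth:
- compound 1 `Cc1ccc2c(O)cc(-c3cccc(Cl)c3)nc2n1`: 41.7 nM
- compound 2 `Cc1cccc(-c2cc(O)c3ccc(C)nc3n2)c1`: 17.8 nM
- compound 3 `Cc1ccc2c(O)cc(-c3ccc4ccccc4c3)nc2n1`: 3800 nM

Of these three, compound 2 gives the lowest number, at 17.8 nM. Compound 1 stands closest to it at 41.7 nM, and compound 3 lies much higher at 3800 nM.

The next compound is compound 4 `Cc1cccc(-c2cc(O)c3c(C)cc(C)nc3n2)c1`, which has not yet been measured. It keeps everything in compound 2 and takes a methyl in place of hydrogen on an aromatic carbon.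

Among the measured compounds shown here, only one measured step bears on this change, and only indirectly: a 2.3-fold lower number from compound 1 to compound 2 (0.37 log units; beyond the scatter). That step is modest, but it exchanges chloro for methyl at a different aromatic carbon, so it gives only a rough scale. For the measured compounds named here, no measured compound shows what a methyl does at the new place. The size of a single-atom step in this assay therefore remains uncertain, and a modest move is the most reasonable expectation. Since compound 2 already holds the lowest value at 17.8 nM, a slight rise is thought more likely than a further fall.

The expected change is a 2.0-fold higher number from compound 2 to compound 4 (0.29 log units; within the scatter). Compound 4 is estimated at 35 nM. Its expected range runs from 10 nM to 150 nM.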

Compound 4, concentration for 50% growth inhibition: 44700 nM
For compound 4 the middle estimate is 1300-fold (3.11 log units) below the measured one, and the stated range ends below it.
By their numbers in this assay, from the lowest: compound 2; then compound 1; then compound 3; then compound 4.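

In this assay, one methyl in place of hydrogen on the aromatic carbon opposite the ring nitrogen gives a 2500-fold higher number from compound 2 to compound 4 (3.40 log units; beyond the scatter), a large step from a change of a single heavy atom. Among the compounds shown here, the only earlier one-place step, a 2.3-fold lower number from compound 1 to compound 2 (0.37 log units; beyond the scatter), was modest and lay at a different aromatic carbon, so it gave no sign that this position could be so sensitive: the change takes compound 2, which has the lowest number of the four compounds, to compound 4, which has the highest. Nothing measured here accounts for a step of this size.

As far as these compounds go, what stays open is whether the sharp rise belongs to the methyl alone or would appear with any group on this carbon, since a fluorine atom, a methoxy group or an amine at the same place would each test that in a different way. Also open, from the compounds shown here alone, is whether the same methyl would have a comparable effect on compound 1, which carries chloro in place of the methyl on the outer aromatic ring of compound 2.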